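A few compounds are considered here, and "the series" means these few. Any claim that something is new, unique, unknown or untested is made for them only; others in the source may bear on it.

Compound 1 `CCCNc1ccc(NC(=O)c2cc(Cl)ccc2O)c(Cl)c1`: 22500 nM
Compound 2 `CCN(CC)c1ccc(NC(=O)c2cc(Cl)ccc2O)c(Cl)c1`: 55500 nM
Compound 3 `O=C(Nc1ccc(NCc2ccccc2)cc1Cl)c1cc(Cl)ccc1O`: 19700 nM

All three values come from an ADME assay on A549 cells (Homo sapiens) for cytotoxicity, read by resazurin assay, with a stated time of 48 h; on this read-out lower numbers stand for higher toxicity in this test and higher numbers for lower toxicity in this test. Compound 3, at 19700 nM, sits level with compound 1 within the scatter, and both lie below compound 2. Compound 4 `O=C(Nc1ccc(NCc2ccc(O)cc2)cc1Cl)c1cc(Cl)ccc1O` carries one change: hydroxy in place of hydrogen on an aromatic carbon. This places hydroxy in place of hydrogen on an aromatic carbon, para to a large group.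

Within the data shown here, no measured pair tests a hydroxy group directly. The closest evidence is the change of group on the nitrogen, which gave a 1.1-fold lower number from compound 1 to compound 3 (0.06 log units; within the scatter) and a 2.8-fold lower number from compound 2 to compound 3 (0.45 log units; beyond the scatter). Both steps are small, so in this assay only a slight rise, not clearly beyond the scatter, is expected: a 1.2-fold higher number from compound 3 to compound 4 (0.09 log units; within the scatter). The estimate for compound 4 is 24000 nM, with an expected range of 10000 nM to 60000 nM.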

Compound 4, half-maximal cytotoxic concentration: 116000 nM
Beside the measured number, compound 4's estimate is 4.8-fold (0.68 log units) below it; the whole stated range lies below it.
By their numbers in this assay, from the lowest: compounds 3 and 1 (each within the scatter of the next); then compound 2; then compound 4.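

In this assay, hydroxy on the benzylamino group moves the number more than any earlier change on that nitrogen, with a 5.9-fold higher number from compound 3 to compound 4 (0.77 log units; beyond the scatter) on adding this one group. The (4-hydroxybenzyl)amino group also rises above the other two nitrogen groups, with a 2.1-fold higher number from compound 2 to compound 4 (0.32 log units; beyond the scatter) and a 5.2-fold higher number from compound 1 to compound 4 (0.71 log units; beyond the scatter), so compound 4 is the least toxic of the four in this test. Nothing available explains this shift. Still open, from the compounds shown here alone, is whether hydroxy itself matters or other groups would do the same. A methoxy, an amine or a carboxylic acid at that place would help to separate these.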